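From pyrimidin-5-yl to pyridin-3-yl on a shared core

This account rests on a few compounds, and the source may have more. Where it says the series, first, only, none or still open, it means among the compounds named here.

Compound 3 (`N#Cc1ccc(N2CCc3cc(-c4cncnc4)ccc3C2)cc1C(F)(F)F`) stands without a number in a functional assay on CWR22R cells (Homo sapiens) for antiproliferative activity, read by CCK-8 assay, with a stated time of 6 days (a lower number here means a stronger inhibitor, a higher number a weaker inhibitor), where its entry reads "not determined" (no result reported) and nothing more. Two related compounds supply the only context. Compound 1 (`N#Cc1ccc(N2CCc3cc(-c4cnc5ccccc5c4)ccc3C2)cc1C(F)(F)F`) shares the core of compound 3, and in this assay compound 1 gives 25900 nM as its result. Compound 2 (`CCN(c1ccc(C#N)c(Cl)c1)c1cc(-n2ccnc2)ccc1C`) gives > 30000 nM in this assay as its result, a limit of the assay and not a number (the limit of > 30000 nM in this assay, at which 1 of the 3 values shown sits).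

The next structure is compound 4 (`N#Cc1ccc(N2CCc3cc(-c4cccnc4)ccc3C2)cc1C(F)(F)F`). It carries pyridin-3-yl in place of pyrimidin-5-yl on an aromatic carbon. Both groups are six-membered aromatic rings. For the measured compounds named here, no measured pair of compounds shows what this swap does, and compound 3 offers no number to start from. In this assay the expected step for this swap is none beyond the usual scatter, in either direction. Going by the values given here, the expectation therefore leans on compound 1 with its 25900 nM result, the only true number on this core. The assay may also report only a limit for the new compound. Compound 4 is expected near 14000 nM with an estimated range (3000 nM to 30000 nM).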

Compound 4, half-maximal inhibitory concentration: 4790 nM
The estimate for compound 4 lay 2.9-fold (0.47 log units) above the measured number, and the stated range covers the measured number.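

On this core, the group on the aromatic carbon clearly affects the result. In this assay, replacing quinolin-3-yl with pyridin-3-yl gives a 5.4-fold lower number from compound 1 to compound 4 (0.73 log units; beyond the scatter), a modest step but one beyond the usual scatter, and the only step shown that can be read as a number. Since a lower number means a stronger inhibitor, compound 4 is the stronger of this pair, so the shared core does not fix the result alone, and this one position can shift it measurably.

The step from compound 3 to compound 4 cannot be read, as compound 3 has no result, so the effect of exchanging pyrimidin-5-yl for pyridin-3-yl stays unknown, and the compounds shown also leave open what an amine, a carboxylic acid or a longer chain on this aromatic carbon would do. Nothing measured here accounts for the difference between quinolin-3-yl and pyridin-3-yl, so that step stands as an observation without an explanation.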